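The source may report more compounds than this note shows. Statements on the series, on what has been measured and on what is new or still open speak of the compounds shown alone.

Values so far in a functional assay (Homo sapiens) for antiproliferative activity, read by sulforhodamine B assay, with a stated time of 48 h (a higher number here means a weaker inhibitor, a lower number a stronger inhibitor), are as follows
- compound 1 `CCc1cccc(NS(=O)(=O)c2ccc(N3CCNC3=O)cc2)c1` gives 270 nM
- compound 2 `Cc1ccc(C)c(NS(=O)(=O)c2ccc(N3CCNC3=O)cc2)c1` gives 86 nM
- compound 3 `O=C1NCCN1c1ccc(S(=O)(=O)Nc2cccc(Cl)c2)cc1` gives 190 nM

Compound 3, at 190 nM in this assay, stands level with compound 1 within the scatter (a 1.4-fold lower number from compound 1 to compound 3 (0.15 log units; within the scatter)). Compound 2 has the lowest number of the three, and the gap to it is beyond the scatter (a 2.2-fold higher number from compound 2 to compound 3 (0.34 log units; beyond the scatter)).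

The next compound, compound 4 `COc1cccc(NS(=O)(=O)c2ccc(N3CCNC3=O)cc2)c1`, carries methoxy in place of chloro on an aromatic carbon, meta to a large group (methoxy in place of chloro on an aromatic carbon). Going by the values given here, no measured compound here carries methoxy. The closest evidence is compound 3 against compound 1, where chloro in place of ethyl on that carbon gave only a small step (a 1.4-fold lower number from compound 1 to compound 3 (0.15 log units; within the scatter)). The modest step to the 2,5-dimethylphenyl compound (a 3.1-fold lower number from compound 1 to compound 2 (0.50 log units; beyond the scatter)) alters the ring differently and bears less directly. No step beyond the scatter is therefore expected in this assay, and no direction is favoured. The estimated step is small (a 1.1-fold higher number from compound 3 to compound 4 (0.04 log units; within the scatter)). For compound 4 the expected value is 210 nM in this assay, with an estimated range from 90 nM to 480 nM as its bounds.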

Compound 4, half-maximal inhibitory concentration: 370 nM
Beside the measured number, compound 4's estimate is 1.8-fold (0.25 log units) below it, within the range that was stated.
By their numbers in this assay, from the lowest: compound 2; then compounds 3, 1 and 4 (each within the scatter of the next).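

In this assay, this carbon, meta to a large group, now carries methoxy as well as chloro and ethyl, and the three compounds stand level: methoxy in place of chloro gives no step beyond the scatter (a 1.9-fold higher number from compound 3 to compound 4 (0.29 log units; within the scatter)), nor does methoxy in place of ethyl (a 1.4-fold higher number from compound 1 to compound 4 (0.14 log units; within the scatter)). Adding a hydrogen-bond acceptor at this place therefore leaves the number within the scatter, while the 2,5-dimethylphenyl compound remains apart from the 3-methoxyphenyl compound (a 4.3-fold higher number from compound 2 to compound 4 (0.63 log units; beyond the scatter)). Nothing measured here explains these results.

From the compounds shown here alone, whether an amine or a carboxylic acid on this carbon would also stay level with these three groups remains open. So does whether a single methyl group on the ring would reach the number of compound 2 (86 nM).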